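Hydroxymethyl to Formyl on a Chain Already at the Limit

A few compounds are considered here, and "the series" means these few. Any claim that something is new, unique, unknown or untested is made for them only; others in the source may bear on it.

Compound 1 `Cn1c(Cc2nn(C)c(=O)c3ccccc23)nnc1SCCCCCCCC(=O)Nc1ccc(Cl)cc1Cl` gives 2200 nM in an assay on 32D cells for inhibition of interleukin-15 (Mus musculus), read by resazurin assay, with stated times of 30 min and 2.5 days, in the presence of a further agent that is not named here; on this read-out higher numbers stand for weaker inhibition and lower numbers for stronger inhibition. Compound 2 `Cn1c(Cc2nn(CCCO[Si](C)(C)C(C)(C)C)c(=O)c3ccccc23)nnc1SCCCCCCCC(=O)Nc1ccc(Cl)cc1Cl` reaches only a limit of this assay, reported as > 30000 nM. Compound 3 `Cn1c(Cc2nn(CCCO)c(=O)c3ccccc23)nnc1SCCCCCCCC(=O)Nc1ccc(Cl)cc1Cl` likewise sits at a limit in this assay, recorded as > 30000 nM. The steps of an at least 13-fold higher number from compound 1 to compound 2 (1.13 log units; beyond the scatter) and an at least 13-fold higher number from compound 1 to compound 3 (1.13 log units; beyond the scatter) are both large, while the step that the two limits leave unreadable from compound 2 to compound 3 cannot be sized because of the limit of > 30000 nM in this assay, at which 2 of the 3 values shown sit. Compound 4 `Cn1c(Cc2nn(CCC=O)c(=O)c3ccccc23)nnc1SCCCCCCCC(=O)Nc1ccc(Cl)cc1Cl` carries formyl in place of hydroxymethyl on a saturated chain carbon, two bonds along the chain from an aromatic nitrogen. Within the data shown here, no measured step tests this exchange directly; both chains on the aromatic nitrogen drove the number from compound 1 to the limit, so compound 4 is expected to remain near that limit in this assay, an expected step of a number no higher from compound 3 to compound 4 (the limit leaves the size open). Compound 4 is estimated at 30000 nM, in a range from 8000 nM to 100000 nM.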

Compound 4, half-maximal inhibitory concentration: 8900 nM
For compound 4 the middle estimate is 3.4-fold (0.53 log units) above the measured one; the range from low to high includes it.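

Formyl in place of hydroxymethyl gives an at least 3.3-fold lower number from compound 3 to compound 4 (0.52 log units; beyond the scatter) in this assay, so a chain at this place does not by itself hold the number at the limit. The exchange of the larger group for formyl reads the same way, with an at least 3.3-fold lower number from compound 2 to compound 4 (0.52 log units; beyond the scatter). Even so, a gap to the parent remains, with a 4.0-fold higher number from compound 1 to compound 4 (0.61 log units; beyond the scatter).

The first two steps are only bounds: the limit of > 30000 nM in this assay, at which 2 of the 4 values shown sit. As far as these compounds go, whether a carboxylic acid or an amine in place of the formyl, or a longer chain, would close the remaining gap stays open.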